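Swapping the halogenated aryl group on a shared core

The compounds below may be only part of what the source reports. "The series", "measured", "known", "first", "only" and "open" are said of these compounds alone.

Three compounds share one core and differ only in the aryl group attached to an aromatic nitrogen. Compound 1 `Cn1ccc2c(Oc3ccc(NC(=O)c4cc5cccnc5n(-c5ccc(Br)cc5)c4=O)cc3)ccnc21` and compound 2 `Cn1ccc2c(Oc3ccc(NC(=O)c4cc5cccnc5n(-c5ccc(Cl)cc5)c4=O)cc3F)ccnc21` carry entries without a number: in a functional assay on NCI-H460 cells (Homo sapiens) for antiproliferative activity, read by MTT assay, with a stated time of 72 h (on this read-out higher numbers stand for weaker inhibition and lower numbers for stronger inhibition), compound 1 is recorded as "not determined" (no result reported), and in this assay compound 2 is recorded as "not determined" (no result reported). The only measured figure belongs to compound 3 `Cn1ccc2c(Oc3ccc(NC(=O)c4cc5cccnc5n(-c5ccc(Br)cc5)c4=O)cc3F)ccnc21`, which in this assay gives 420 nM. Compound 3 therefore stands alone, with nothing to rank it against.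

Compound 4 `Cn1ccc2c(Oc3ccc(NC(=O)c4cc5cccnc5n(-c5ccc(C(F)(F)F)cc5Cl)c4=O)cc3F)ccnc21` differs from compound 3 in one place: 2-chloro-4-(trifluoromethyl)phenyl in place of 4-bromophenyl on an aromatic nitrogen. Within the data shown here, no measured pair shows what such a swap does on this core, so the direction of the step cannot be read from the data. The expectation is a modest change, most likely not far beyond the usual scatter. Compound 4 is estimated at 350 nM, within a range from 100 nM to 1500 nM. The estimated step from compound 3 to compound 4 is a 1.2-fold lower number from compound 3 to compound 4 (0.08 log units; within the scatter).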

Compound 4, half-maximal inhibitory concentration: 6010 nM
The estimate for compound 4 lay 17-fold (1.23 log units) below the measured number; the whole stated range lies below it.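

In this assay, the aryl group on the aromatic nitrogen proves able to change the read-out a great deal: the swap gives a 14-fold higher number from compound 3 to compound 4 (1.16 log units; beyond the scatter), which on this read-out means much weaker inhibition. This position on the shared core is therefore sensitive to what it carries, and of these two groups 4-bromophenyl gives clearly the stronger inhibition. Nothing available explains why this swap weakens inhibition so strongly.

The new group differs from 4-bromophenyl in more than one way, carrying both a chlorine and a trifluoromethyl group, so the part played by each cannot be separated, and compounds 1 and 2 offer no number to compare. On these data alone, how a phenyl ring carrying an amine or a carboxylic acid would behave at this position remains open.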